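Working notes: from compound 3 to compound 4

The source may hold more compounds than are shown below. What is called first, only, known or untested is meant among the compounds shown, and "the series" means these compounds.

Measured in a functional assay on KB cells (Homo sapiens) for inhibition; on this read-out lower numbers stand for stronger inhibition and higher numbers for weaker inhibition:
- Compound 1 `Cc1cccc(Cn2c(N)nc3cc(Cl)c(Cl)cc32)c1`: 65000 nM
- Compound 2 `Clc1cc2nc(Cl)n(Cc3ccccc3)c2cc1Cl`: > 100000 nM (a limit)
- Compound 3 `Cc1cccc(Cn2c(Cl)nc3cc(Cl)c(Cl)cc32)c1`: > 100000 nM (a limit)

Compound 3 has no numerical value, only the limit > 100000 nM. The series is dominated by the limit of > 100000 nM in this assay, at which 2 of the 3 values shown sit.

Compound 4 `O=[N+]([O-])c1cccc(Cn2c(Cl)nc3cc(Cl)c(Cl)cc32)c1` carries nitro in place of methyl on an aromatic carbon, meta to a large group (nitro in place of methyl on an aromatic carbon). Going by the values given here, no measured step makes this exchange, so the evidence is indirect. Chloro in place of amino on an aromatic carbon gives an at least 1.5-fold higher number from compound 1 to compound 3 (0.18 log units; that floor lies within the scatter). Methyl in place of hydrogen on an aromatic carbon gives a step that the two limits leave unreadable from compound 2 to compound 3. Neither step gives a readable size for a change on this core, so no step beyond the scatter is expected in this assay, and no direction can be assigned. A result reported only as a limit is the likeliest outcome.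

The expected change is an at least 1.1-fold lower number from compound 3 to compound 4 (0.04 log units; that floor lies within the scatter). For compound 4 the estimate is 90000 nM, with an expected range of 35000 nM to 150000 nM.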

Compound 4, half-maximal inhibitory concentration: 239000 nM
Beside the measured number, compound 4's estimate is 2.7-fold (0.42 log units) below it; measured number outside the range, above it.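

Compound 4 gives no readable new step against compound 2 or compound 3, since both of those compounds stand only as limits: the limit of > 100000 nM in this assay, at which 2 of the 4 values shown sit. The compounds shown leave open how far nitro in place of methyl or hydrogen on an aromatic carbon shifts the number on the shared core.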